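Series notes: half-life on human liver microsomes

The source may report more compounds than this note shows. Statements on the series, on what has been measured and on what is new or still open speak of the compounds shown alone.

Measured so far:
compound 1 `CC(C)(/C=C1\OC(=O)NC1=O)c1ccc(-c2ccc3cccc(F)c3c2)[nH]c1=O` — 1.89 h
compound 2 `O=C1NC(=O)/C(=C/C(c2ccc(-c3ccc4cccc(F)c4c3)[nH]c2=O)C2CCCCC2)O1` — 1.09 h
compound 3 `CC(C)C(c1ccc(-c2ccc3cccc(F)c3c2)[nH]c1=O)C1SC(=O)NC1=O` — 1.87 h

The read-out throughout is an ADME assay on microsomes from liver (Homo sapiens) for metabolic stability; on this read-out higher numbers stand for a longer-lived compound and lower numbers for a shorter-lived compound. In this assay compound 1 gives 1.89 h, compound 2 gives 1.09 h and compound 3 gives 1.87 h. The three numbers sit close together: compound 2 lies within the usual scatter of compound 3 and also within the usual scatter of compound 1, so no ordering among the three measured compounds can be read from these values. Among the measured compounds shown here, no pair of measured compounds differs in a single place, so no single-point step has been quantified.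

Compound 4 `O=C1NC(=O)/C(=C/C(c2ccccc2)c2ccc(-c3ccc4cccc(F)c4c3)[nH]c2=O)O1` is not yet measured. Relative to compound 2 the change is phenyl in place of cyclohexyl on a saturated chain carbon bound to an aromatic carbon and a double-bonded chain carbon. With no measured step of this kind in the set, the expectation rests on the narrow spread of the three measured values alone. For compound 4 the step from compound 2 is expected to be a 1.2-fold higher number from compound 2 to compound 4 (0.08 log units; within the scatter), that is, no change beyond the scatter in either direction. Compound 4 is therefore estimated at 1.3 h, with a plausible range of 0.6 h to 2.8 h.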

Compound 4, half-life: 2.1 h
Compound 4: middle estimate off by 1.6-fold (0.21 log units), on the low side; measured number inside the range.
By their numbers in this assay, from the lowest: compounds 2, 3, 1 and 4 (each within the scatter of the next).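

In this assay, among the compounds shown here, phenyl in place of cyclohexyl on a saturated chain carbon bound to an aromatic carbon and a double-bonded chain carbon gives a 1.9-fold higher number from compound 2 to compound 4 (0.28 log units; within the scatter), the first step that isolates a single place. At this position on this core, the read-out therefore does not separate the six-membered non-aromatic ring from the six-membered aromatic ring, although the step sits close to the edge of the scatter and a repeat measurement could matter for how it is read. No supporting measurement is available to explain the result for this pair.

The notes leave open whether a group of a different kind on the same saturated chain carbon, such as an amine, a carboxylic acid or a longer chain, would give a step beyond the scatter. Also open, on these data alone, is whether phenyl in place of cyclohexyl reads the same way on the core of compound 3, where the chain carries a different ring and no double bond.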